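This account rests on a few compounds, and the source may have more. Where it says the series, first, only, none or still open, it means among the compounds named here.

Compound 1, with the structure `FC(F)(F)c1ccc(CN2CCN(Cc3cc(-c4ccc(OCc5ccccc5)cc4)on3)CC2)cc1`, was tested in a functional assay on Huh-7 cells (Homo sapiens) for antiproliferative activity, read by sulforhodamine B assay, with a stated time of 72 h (a lower number here means a stronger inhibitor, a higher number a weaker inhibitor), where compound 1 gives 1700 nM. Compound 2, with the structure `Fc1cccc(COc2ccc(-c3cc(CN4CCN(Cc5ccc(C(F)(F)F)cc5)CC4)no3)cc2)c1`, carries one alteration relative to compound 1: fluoro in place of hydrogen on an aromatic carbon. In this assay compound 2 gives 1300 nM, so the alteration produced a 1.3-fold lower number from compound 1 to compound 2 (0.12 log units; within the scatter), a step that stays inside the usual spread of repeated measurements.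

Compound 3, with the structure `N#Cc1cccc(COc2ccc(-c3cc(CNC4CCN(Cc5ccccc5)CC4)no3)cc2)c1`, has a different core; how the two cores differ from compound 1 is not broken down here. In this assay compound 3 gives 2500 nM, and this number sits within the usual scatter of the numbers for compound 1 and compound 2, so no ordering among the three is supported.

Compound 4, with the structure `N#Cc1cccc(COc2ccc(-c3cc(CNC4CCN(Cc5ccccc5)CC4)no3)cc2F)c1`, has not yet been measured. It differs from compound 3 in one place: fluoro in place of hydrogen on an aromatic carbon. Within the data shown here, this is the same kind of change as the one from compound 1 to compound 2, though the surroundings differ: in compound 4 the new fluorine sits ortho to a (3-cyanobenzyl)oxy group and meta to a large group, whereas in compound 2 it sits meta to a large group only. Because the earlier instance gave a 1.3-fold lower number from compound 1 to compound 2 (0.12 log units; within the scatter), a step of about a 1.3-fold lower number from compound 3 to compound 4 (0.10 log units; within the scatter) is expected here as well. Compound 4 is therefore estimated to give 2000 nM in this assay, with a likely range from 1000 nM to 4000 nM.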

Compound 4, half-maximal inhibitory concentration: 2300 nM
Estimate against measurement, compound 4: 1.2-fold (0.06 log units) below; measured number inside the range.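

In this assay, fluoro in place of hydrogen on the aromatic carbon ortho to a (3-cyanobenzyl)oxy group gives a 1.1-fold lower number from compound 3 to compound 4 (0.04 log units; within the scatter), so this step stays inside the usual spread of repeated measurements. Set beside the earlier instance of the same change, the new step tells the same story on a second core: the same change on two cores in this assay, a 1.3-fold lower number (0.12 log units; within the scatter) from compound 1 to compound 2 and a 1.1-fold lower number (0.04 log units; within the scatter) from compound 3 to compound 4, 1.2-fold (0.08 log units) apart, within the scatter of two such steps. This shows that the change carried from one core to the other without a step that can be told apart from scatter, but it does not show that fluoro lowers the number on either core, and with the fluorine in different surroundings in the two instances, it says nothing about whether one placement is better than the other.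

The compounds shown leave open whether a different group at the same place, such as chlorine, a methoxy group or an amine, would move the number beyond the scatter. They also leave open whether the fluoro change would stay this small on cores other than these two, or in a read-out other than this antiproliferative one.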